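The source may report more compounds than this note shows. Statements on the series, on what has been measured and on what is new or still open speak of the compounds shown alone.

Compound 2 `CCCCC(Sc1ccc(OCCCOc2cccc(C(C)C)c2)cc1)C(=O)O` gives 6000 nM in an assay for inhibition of Polyunsaturated fatty acid 5-lipoxygenase (Homo sapiens), read by HPLC, with a stated time of 10 min; a lower number here means a stronger inhibitor, a higher number a weaker inhibitor. Compound 1 `CCCCC(Sc1ccc(OCCCOc2cccc(C(F)(F)F)c2)cc1)C(=O)O` gives 9800 nM in this assay, and the step of a 1.6-fold lower number from compound 1 to compound 2 (0.21 log units; within the scatter) lies within the scatter, so the two stand level on the numbers shown. Compound 3 `CCCCC(Sc1ccc(OCCCOc2ccc(C)cc2)cc1)C(=O)O` differs from compound 2 by 4-methylphenyl in place of 3-isopropylphenyl on an oxygen on a saturated carbon. Within the data shown here, the only measured step, a 1.6-fold lower number from compound 1 to compound 2 (0.21 log units; within the scatter), concerns a different substituent on the same aryl ether and was within the scatter, which gives no basis for expecting a step beyond the scatter here. The expected step of a 1.3-fold higher number from compound 2 to compound 3 (0.12 log units; within the scatter) therefore carries no firm direction. The estimate for compound 3 in this assay is 8000 nM, with a range from 3000 nM to 20000 nM.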

Compound 3, half-maximal inhibitory concentration: > 10000 nM
Compound 3: no number, only a limit; the forecaster's own chance of this, stated with the estimate: 10%; at least 1.2-fold (0.09 log units) between middle value and limit.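

In this assay compound 3 carries a limit and not a number: the limit of > 10000 nM in this assay, at which 1 of the 3 values shown sits. Exchanging the aryl group on an oxygen on a saturated carbon for 4-methylphenyl gives an at least 1.6-fold higher number from compound 2 to compound 3 (0.22 log units; that floor lies within the scatter), and set against 3-(trifluoromethyl)phenyl it gives an at least 1.0-fold higher number from compound 1 to compound 3 (0.00 log units; that floor lies within the scatter). Both floors lie within the scatter, so neither step has a fixed size, and 4-methylphenyl shows no gain over either group.

Whether 4-methylphenyl differs through its methyl group or through where that group sits remains unresolved. On these data alone, the effect of an amine or a carboxylic acid on this aryl group also remains open.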